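Notes on an oxadiazole-linked biphenyl ether series

A few compounds are considered here, and "the series" means these few. Any claim that something is new, unique, unknown or untested is made for them only; others in the source may bear on it.

Measured compounds:
- compound 1, `Clc1ccc(-c2nnc(COc3ccc(-c4ccccc4)cc3)o2)cc1`: 75%
- compound 2, `Clc1ccc(COc2nnc(COc3ccc(-c4ccccc4)cc3)o2)c(Cl)c1`: 29.5%

In a functional assay on the whole organism (strain Wistar) for inhibition, with Rattus norvegicus as the target, read by paw edema, with a stated time of 3 h, at a dose of 10 mg/kg by the oral route (a lower number here means less inhibition, a higher number more inhibition at the dose given (going by the name of the read-out)), compound 1 gives 75%, the higher of the two numbers available. Its nearest neighbour is compound 2, which in this assay gives 29.5%, a gap that lies beyond the scatter of the measurement. Going by the values given here, no pair of measured compounds differing in a single place is available, so the effect of any one change on the shared core of compound 1 cannot be read off directly.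

Compound 3, `Fc1ccc(Nc2nnc(COc3ccc(-c4ccccc4)cc3)o2)cc1`, has not yet been measured. It differs from compound 1 by (4-fluorophenyl)amino in place of 4-chlorophenyl on an aromatic carbon. With the two measured compounds both far apart in structure from compound 3, the size of the step from compound 1 to compound 3 in this assay is expected to be a moderate loss of inhibition, possibly beyond the scatter. For compound 3 a value of 55% is estimated in this assay, within a range of 35% to 75%, and the expected step is a number 20 percentage points lower from compound 1 to compound 3 (beyond the scatter).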

Compound 3, a percentage reported as inhibition, in the whole organism at one dose (the size of the read-out at that dose, not a potency): 52.3%
Beside the measured number, compound 3's estimate is 2.7 percentage points above it; the measured number falls inside the stated range.
By their numbers in this assay, from the lowest: compound 2; then compound 3; then compound 1.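

In this assay, compound 3 gives the series its first pair differing in one place: on the aromatic carbon next to the ring nitrogen and next to the ring oxygen, (4-fluorophenyl)amino in place of 4-chlorophenyl gives a number 22.7 percentage points lower from compound 1 to compound 3 (beyond the scatter) on the shared core. The position therefore responds to this change, yet the aryl group carried through an amino nitrogen still leaves compound 3 at 52.3% at the dose given. No measurement bearing on the reason for this step is at hand.

This single swap alters both the halogen and the attachment through nitrogen, so the two contributions cannot be separated. A (4-chlorophenyl)amino or a 4-fluorophenyl group at this carbon would separate them, while an unsubstituted amine or a methyl group would show how much of the aryl group this position needs.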